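This account rests on a few compounds, and the source may have more. Where it says the series, first, only, none or still open, it means among the compounds named here.

Measured compounds:
- compound 1, `CCCCNC(=O)Oc1ccc(Cl)cc1C(=O)Nc1cccc(Cl)c1`: 64 h
- compound 2, `CCCCCNC(=O)Oc1ccc(Cl)cc1C(=O)Nc1cccc(Cl)c1`: 64 h
- compound 3, `CCNC(=O)Oc1ccc(Cl)cc1C(=O)Nc1ccc(Cl)c(Cl)c1`: 64 h

All three values come from an ADME assay for metabolic stability, read by HPLC, at pH 7; a higher number here means that the compound lasts longer, a lower number that the compound disappears faster. In this assay compound 1 gives 64 h, and in this assay compound 2 gives 64 h. The step between them, no change at the digits printed from compound 1 to compound 2 (within the scatter), corresponds to methyl in place of hydrogen on a saturated chain carbon, four bonds along the chain from an amide-type nitrogen. In this assay compound 3 gives 64 h, which stands level with compounds 1 and 2 within the scatter; the difference between the core of compound 3 and the core of compound 1 is not broken down here.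

Compound 4, `CCCNC(=O)Oc1ccc(Cl)cc1C(=O)Nc1ccc(Cl)c(Cl)c1`, is not yet measured. It differs from compound 3 by methyl in place of hydrogen on a saturated chain carbon, two bonds along the chain from an amide-type nitrogen. This is the same kind of change as the one from compound 1 to compound 2, found in two pairs among these compounds, but not the same change: in the measured pair the entering methyl sits four bonds along the chain from an amide-type nitrogen, whereas in compound 4 it sits two bonds along the chain from an amide-type nitrogen. Among the measured compounds shown here, the only guide to the size of the step is the measured pair. Because no change at the digits printed from compound 1 to compound 2 (within the scatter) showed no change within the scatter, a step of similar size, no change at the digits printed from compound 3 to compound 4 (within the scatter), is expected from compound 3 to compound 4 in this assay, with added uncertainty from the different place of the methyl. Compound 4 is therefore estimated at 64 h, with a range from 32 h to 128 h in this assay.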

Compound 4, half-life: 64 h
Estimate against measurement, compound 4: no gap at the digits printed, and the stated range covers the measured number.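

In this assay, the methyl on the core of compound 3 gives no change at the digits printed from compound 3 to compound 4 (within the scatter), and the same change on the core of compound 1 gives a step that matches it: the same change on two cores in this assay, no change at the digits printed (within the scatter) from compound 1 to compound 2 and no change at the digits printed (within the scatter) from compound 3 to compound 4, 1.0-fold (0.00 log units) apart, within the scatter of two such steps

Within these two pairs, then, the change carries from one core to the other without a readable difference in half-life, even though the entering methyl sits four bonds along the chain from an amide-type nitrogen in one pair and two bonds along it in the other. This does not make a rule for the series: two pairs that both show no readable step cannot say how the change would carry over on a core where it produces a step beyond the scatter, nor can they separate any influence of the core from that of the place of the methyl.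

The compounds shown leave open how half-life responds on the amide-type nitrogen to a branched chain, a chain longer than those here, or a chain carrying an amine or a carboxylic acid. Also open, from the compounds shown here alone, is whether a nitrile or a methoxy group in place of a chloro group would hold the half-life level in this assay.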